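The source may hold more compounds than are shown below. What is called first, only, known or untested is meant among the compounds shown, and "the series" means these compounds.

Measured so far in a functional assay for inhibition of sodium/hydrogen exchanger (Oryctolagus cuniculus); on this read-out lower numbers stand for stronger inhibition and higher numbers for weaker inhibition:
compound 1 `Cc1cc(Cl)c(S(C)(=O)=O)cc1C(=O)N=C(N)N` — 25 nM
compound 2 `CSc1cc(C)c(C(=O)N=C(N)N)cc1S(C)(=O)=O` — 6 nM
compound 3 `Cc1cc(SC(C)(C)C)c(S(C)(=O)=O)cc1C(=O)N=C(N)N` — 22 nM

Compound 3 gives the second highest of the three numbers. Its nearest neighbour is compound 1, at a 1.1-fold lower number from compound 1 to compound 3 (0.06 log units; within the scatter), so these two cannot be told apart. Compound 2 stands clearly apart: a 3.7-fold higher number from compound 2 to compound 3 (0.56 log units; beyond the scatter).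

Compound 4 `Cc1cc(-n2ccnc2C)c(S(C)(=O)=O)cc1C(=O)N=C(N)N` is compound 3 with one change: 2-methyl-1H-imidazol-1-yl in place of (tert-butyl)sulfanyl on an aromatic carbon.

For the measured compounds named here, two measured steps bear on this position. Exchanging chloro for (tert-butyl)sulfanyl gave a 1.1-fold lower number from compound 1 to compound 3 (0.06 log units; within the scatter), while exchanging chloro for methylsulfanyl gave a 4.2-fold lower number from compound 1 to compound 2 (0.62 log units; beyond the scatter). Three different groups at this carbon therefore span a modest band of numbers, with no group larger than (tert-butyl)sulfanyl and no aromatic ring tried there. Going by the values given here, no measured step speaks directly to a 2-methyl-1H-imidazol-1-yl group, so the expectation stays close to compound 3 with a broad range: the step to compound 4 is estimated at a 1.1-fold lower number from compound 3 to compound 4 (0.04 log units; within the scatter), that is, none beyond the scatter. Compound 4 is accordingly expected at 20 nM, range 5 nM to 80 nM.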

Compound 4, half-maximal inhibitory concentration: 29 nM
Estimate against measurement, compound 4: 1.5-fold (0.16 log units) below, and the stated range covers the measured number.
By their numbers in this assay, from the lowest: compound 2; then compounds 3, 1 and 4 (each within the scatter of the next).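

In this assay, a five-membered aromatic ring is accepted on this carbon, ortho to the methylsulfonyl group: 2-methyl-1H-imidazol-1-yl in place of (tert-butyl)sulfanyl gives a 1.3-fold higher number from compound 3 to compound 4 (0.12 log units; within the scatter), and in place of chloro it gives a 1.2-fold higher number from compound 1 to compound 4 (0.06 log units; within the scatter), so these three groups cannot be told apart here despite their different sizes and shapes. Methylsulfanyl alone stands apart among the four groups at this carbon, now also against the new ring, with a 4.8-fold higher number from compound 2 to compound 4 (0.68 log units; beyond the scatter). Nothing available on these compounds accounts for that separation.

Open, going by these compounds, is whether the methyl of the 2-methyl-1H-imidazol-1-yl group affects the number, which an unsubstituted imidazol-1-yl would address. Also open, on these data alone, is how a phenyl ring, a dimethylamino group or an ethylsulfanyl group at this carbon would compare with methylsulfanyl.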